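Replacing 3-chlorophenyl with 4-methoxyphenyl in compound 2

The source may report more compounds than this note shows. Statements on the series, on what has been measured and on what is new or still open speak of the compounds shown alone.

Measured in a functional assay on HCT-116 cells (Homo sapiens) for antiproliferative activity, read by MTT assay, with a stated time of 72 h; a lower number here means a stronger inhibitor, a higher number a weaker inhibitor:
compound 1 `NC1=NC2(CCOCC2)N(OCCCOc2ccccc2)C(N)=N1`: 6010 nM
compound 2 `NC1=NC2(CCSCC2)N(OCCCOc2cccc(Cl)c2)C(N)=N1`: 1 nM
compound 3 `NC1=NC2(CCOCC2)N(OCCCOc2ccc(Br)cc2)C(N)=N1`: 320 nM

Compound 2 has the lowest number of the three, beyond the scatter from both others. Compound 4 `COc1ccc(OCCCON2C(N)=NC(N)=NC23CCSCC3)cc1` differs from it in one place, with 4-methoxyphenyl in place of 3-chlorophenyl on an oxygen on a saturated carbon. Among the compounds with values here, no measured step tests this exchange. The closest evidence comes from the core shared by compound 1 and compound 3, where bromo in place of hydrogen on an aromatic carbon gave a large step, a 19-fold lower number from compound 1 to compound 3 (1.27 log units; beyond the scatter). Such a change may therefore matter in this assay, though methoxy itself is untested. Compound 2, at 1 nM, sits so low that a higher number is expected. The expected step, also large, is a 50-fold higher number from compound 2 to compound 4 (1.70 log units; beyond the scatter). For compound 4 the estimated value is 50 nM, with an expected range of 4 nM to 600 nM.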

Compound 4, half-maximal inhibitory concentration: 70 nM
Compound 4: middle estimate off by 1.4-fold (0.15 log units), on the low side; measured number inside the range.
By their numbers in this assay, from the lowest: compound 2; then compound 4; then compound 3; then compound 1.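

In this assay, the exchange of 3-chlorophenyl for 4-methoxyphenyl gives a 70-fold higher number from compound 2 to compound 4 (1.85 log units; beyond the scatter), so the aromatic group on this chain also matters strongly on the core of compound 2. Here the number rises, whereas a 19-fold lower number from compound 1 to compound 3 (1.27 log units; beyond the scatter) on the other core shows a fall, so changes to this aromatic ring can move the number in either direction. Nothing available explains the size of the step.

As far as these compounds go, whether the rise follows the loss of chloro, the gain of methoxy or the different ring position stays open. So does how an amine or a carboxylic acid on this ring would read.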